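A few compounds are considered here, and "the series" means these few. Any claim that something is new, unique, unknown or untested is made for them only; others in the source may bear on it.

The measured compounds in a functional assay on HT-29 cells (Homo sapiens) for antiproliferative activity, read by MTT assay, with a stated time of 72 h; on this read-out higher numbers stand for weaker inhibition and lower numbers for stronger inhibition:

compound 1 `O=C(Nc1ccc(Oc2ccnc3[nH]ccc23)cc1)c1cc2cccnc2n(-c2ccc(F)cc2)c1=O`, giving 160 nM
compound 2 `O=C(Nc1ccc(Oc2ccnc3[nH]ccc23)cc1)c1cc2cccnc2n(-c2ccc(Br)cc2)c1=O`, giving 270 nM
compound 3 `O=C(Nc1ccc(Oc2ccnc3[nH]ccc23)c(F)c1)c1cc2cccnc2n(-c2ccc(F)cc2)c1=O`, giving 36 nM

Compound 3 has the lowest number of the three. Its step from compound 1, a 4.4-fold lower number from compound 1 to compound 3 (0.65 log units; beyond the scatter), lies beyond the scatter, and compound 2 stands a further step away, so compound 3 is the strongest inhibitor in this assay among the measured set.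

Compound 4 `O=C(Nc1ccc(Oc2ccnc3[nH]ccc23)c(F)c1)c1cc2cccnc2n(-c2ccc(Br)cc2F)c1=O` has not been measured. It differs from compound 3 in one place: 4-bromo-2-fluorophenyl in place of 4-fluorophenyl on an aromatic nitrogen. This bundles two changes on the ring carried by the aromatic nitrogen: bromine takes the place of fluorine, and a second fluorine enters that ring. Only the first part has a measured counterpart, a 1.7-fold higher number from compound 1 to compound 2 (0.23 log units; within the scatter), which is within the scatter. Within the data shown here, the second part has no counterpart here; the added fluorine of a 4.4-fold lower number from compound 1 to compound 3 (0.65 log units; beyond the scatter) sits on a different ring of the shared core and says nothing about this one. The expected step is therefore small, a 1.5-fold higher number from compound 3 to compound 4 (0.18 log units; within the scatter), leaning if anything toward a slightly higher number. Compound 4 is estimated at 55 nM, with a range from 20 nM to 150 nM.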

Compound 4, half-maximal inhibitory concentration: 820 nM
The estimate for compound 4 lay 15-fold (1.17 log units) below the measured number; the whole stated range lies below it.
By their numbers in this assay, from the lowest: compound 3; then compounds 1 and 2 (each within the scatter of the next); then compound 4.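

The ring on the aromatic nitrogen is not a place where changes pass without effect: in this assay, 4-bromo-2-fluorophenyl in place of 4-fluorophenyl gives a 23-fold higher number from compound 3 to compound 4 (1.36 log units; beyond the scatter) and is the largest step in this set. The earlier swap on that same ring, a 1.7-fold higher number from compound 1 to compound 2 (0.23 log units; within the scatter) for bromo in place of fluoro, stayed within the scatter, so on the core of compound 1 bromine alone came nowhere near a step of this size. That points to the second fluorine on this ring, or to how the parts of the change combine on the core of compound 3, as the piece still unaccounted for, and nothing available here explains why the number rises so far.

The compounds shown do not separate the two parts of the change, since neither the bromine without the second fluorine nor the second fluorine without the bromine appears on the core of compound 3. They also leave open whether a chlorine or a methyl group in place of that second fluorine would bring a step of similar size.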